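The source may report more compounds than this note shows. Statements on the series, on what has been measured and on what is new or still open speak of the compounds shown alone.

Compound 2 `COC(=O)c1ccc2ccc(C(=O)c3ccccc3)c-2cc1` gives 4.7 in a physicochemical assay for lipophilicity, read by HPLC, measured as octanol-water partition, at pH 11 (a lower number here means a more polar compound, a higher number a more lipophilic compound), and stands second highest of the three numbers: compound 3 `COC(=O)c1ccc2c(C(=O)c3ccccc3)cc(C(=O)c3ccccc3)c-2cc1` gives 5.5, while compound 1 `O=C(NCCO)c1ccc2ccc(C(=O)c3ccccc3)c-2cc1` gives 2.2. Compound 4 `COC(=O)c1ccc2ccc(C(=O)Nc3ccccc3)c-2cc1` differs from compound 2 by anilino in place of phenyl on a carbonyl carbon. Within the data shown here, no measured step covers this exchange. The step of a number 2.50 log units higher from compound 1 to compound 2 (beyond the scatter) swapped an amide for an ester, though that amide also carried a hydroxyl; the step of a number 0.80 log units higher from compound 2 to compound 3 (beyond the scatter) added a benzoyl. Since compound 1, the only amide measured, gives 2.2, a downward step is expected for the new amide. A step smaller than the first is estimated, about a number 0.80 log units lower from compound 2 to compound 4 (beyond the scatter). Compound 4 is therefore expected at 3.9, within 3.3 to 4.5.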

Compound 4, distribution coefficient: 4
Compound 4: middle estimate off by 0.10 log units, on the low side; low and high end bracket the measured number.
By their numbers in this assay, from the lowest: compound 1; then compound 4; then compound 2; then compound 3.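

Earlier steps changed the ester carbonyl or added a benzoyl, whereas this step changes the group on the benzoyl carbonyl carbon itself and shows that this place also moves the number in this assay: anilino in place of phenyl gives a number 0.70 log units lower from compound 2 to compound 4 (beyond the scatter) and brings in one hydrogen-bond donor. Nothing shown gives a measured reason for this step.

Going by these compounds, whether benzylamino, methylamino or a longer chain on this carbonyl carbon would shift the number in the same direction remains open. So does the size of this step with a (2-hydroxyethyl)amino group in place of the methoxy.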